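Compound 3 to compound 4: a chain replaces pyridin-3-yl

A few compounds are considered here, and "the series" means these few. Any claim that something is new, unique, unknown or untested is made for them only; others in the source may bear on it.

Values in an ADME assay on S9 fraction from liver (Rattus norvegicus) for metabolic stability, read by LC-MS, using NADPH, with a stated time of 30 min; on this read-out lower numbers stand for a less stable compound and higher numbers for a more stable compound:
- compound 1 `CCCCCCCCc1ccc(OCC(=O)Cn2nnc(SC)n2)cc1`: < 5% (a limit of the assay)
- compound 2 `CCCCCCCCc1ccc(OCC(=O)Cn2nnc(-c3ccccc3)n2)cc1`: 33%
- compound 3 `CCCCCCCCc1ccc(OCC(=O)Cn2nnc(-c3cccnc3)n2)cc1`: 12%

Compound 1 gives < 5%, which is a limit and not a number. Of the two true numbers, the lower belongs to compound 3 at 12%, and compound 2 stands higher.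

The next change leads to compound 4 `CCCCCCCCc1ccc(OCC(=O)Cn2nnc(CCC(=O)O)n2)cc1`: 2-carboxyethyl in place of pyridin-3-yl on an aromatic carbon. In words, this is 2-carboxyethyl in place of pyridin-3-yl on an aromatic carbon.

Three measured steps swap the group on that carbon: a number at least 28 percentage points higher from compound 1 to compound 2 (beyond the scatter), a number at least 7 percentage points higher from compound 1 to compound 3 (that floor lies within the scatter) and a number 21 percentage points lower from compound 2 to compound 3 (beyond the scatter). The group there clearly matters in this assay, yet none of these steps brings in an open chain, so they set the likely size but hardly the direction. With compound 3 at 12% lying low in the measured span, a small rise, about as large as the scatter, is expected. The expected change is a number 8 percentage points higher from compound 3 to compound 4 (within the scatter). Compound 4 is estimated at 20%, with an expected range of 5% to 50%.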

Compound 4, percent of the compound remaining: < 5%
Compound 4: only a limit was reported; the forecaster's own chance of this, stated with the estimate: 15%; at least 15 percentage points between middle value and limit.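

In this assay compound 4 gives < 5%, which is a limit of the assay and not a number. Among the compounds shown here, this is the first open chain on the carbon of the five-membered aromatic ring, and 2-carboxyethyl in place of phenyl gives a number at least 28 percentage points lower from compound 2 to compound 4 (beyond the scatter), so the chain does not hold the level phenyl gave, while 2-carboxyethyl in place of pyridin-3-yl gives a number at least 7 percentage points lower from compound 3 to compound 4 (that floor lies within the scatter), so only the comparison with phenyl is firm. The step between the two limited compounds cannot be read: the limit of < 5% in this assay, at which 2 of the 4 values shown sit.

On these data alone, it remains open whether the result belongs to the open chain as such or to its carboxylic acid; a plain propyl chain, a methyl ester or a primary amide on this carbon would separate the two. As far as these compounds go, how a longer chain or an amine on this carbon would stand against the phenyl of compound 2 is also open.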